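Shortening the ring linker from compound 1 to compound 4

The source may hold more compounds than are shown below. What is called first, only, known or untested is meant among the compounds shown, and "the series" means these compounds.

Working notes on a three-compound set with a shared core. In a functional assay on CHO cells for antagonist activity at prostaglandin E2 receptor EP3 subtype (Homo sapiens), read by cAMP accumulation, with a stated time of 30 min (on this read-out lower numbers stand for stronger inhibition and higher numbers for weaker inhibition), compound 1 `CC(C)[C@H](C[C@H]1OC(=O)NC1=O)c1ccc(-c2ccc3cccc(F)c3c2)[nH]c1=O` gives 15 nM, the lowest of the three numbers. Compound 2 `C/C(=C1/OC(=O)NC1=O)C(c1ccc(-c2ccc3cccc(F)c3c2)[nH]c1=O)C(C)C` gives 39 nM in this assay, a gap beyond the scatter, and compound 3 `Cc1cc(C(/C=C2\OC(=O)NC2=O)C(C)C)c(=O)[nH]c1-c1ccc2cccc(F)c2c1` gives 92 nM, the furthest from compound 1. Compound 4 `CC(C)[C@@H](c1ccc(-c2ccc3cccc(F)c3c2)[nH]c1=O)[C@@H]1OC(=O)NC1=O` is unmeasured. It differs from compound 1 in one place: 2,4-dioxo-1,3-oxazolidin-5-yl in place of (2,4-dioxo-1,3-oxazolidin-5-yl)methyl on a saturated chain carbon bound to an aromatic carbon and a saturated chain carbon. Within the data shown here, both measured variants of this link, compound 2 and compound 3, sit above compound 1, so a rise beyond the scatter is expected here as well, though the direct one-carbon shortening has no measured precedent. Compound 4 is expected to give 45 nM in this assay, between 12 nM and 170 nM. The expected step is a 3.0-fold higher number from compound 1 to compound 4 (0.48 log units; beyond the scatter).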

Compound 4, half-maximal inhibitory concentration: 610 nM
Estimate against measurement, compound 4: 14-fold (1.13 log units) below, and the stated range ends below it.
By their numbers in this assay, from the lowest: compound 1; then compound 2; then compound 3; then compound 4.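

On a saturated chain carbon bound to an aromatic carbon and a saturated chain carbon, 2,4-dioxo-1,3-oxazolidin-5-yl in place of (2,4-dioxo-1,3-oxazolidin-5-yl)methyl gives, in this assay, a 41-fold higher number from compound 1 to compound 4 (1.61 log units; beyond the scatter). Among these compounds, this is the first direct single-place step in the set, and it shows that this position does not tolerate the shorter link, even though the ring and the counts of hydrogen-bond donors and acceptors stay the same. Nothing available explains the rise.

Open, going by these compounds, is whether a longer chain, such as (2,4-dioxo-1,3-oxazolidin-5-yl)ethyl, would hold the number of compound 1 or lose ground. Also open, on these data alone, is how the other stereoisomers of compound 4 would read.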